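A few compounds are considered here, and "the series" means these few. Any claim that something is new, unique, unknown or untested is made for them only; others in the source may bear on it.

Three compounds have been measured so far in a functional assay on COLO 205 cells (Homo sapiens) for antiproliferative activity, with a stated time of 72 h (a higher number here means a weaker inhibitor, a lower number a stronger inhibitor), as follows:
Compound 1 `C=C[C@@H]1C[C@@H](Cc2ccc(OC)c(O)c2)[C@H]2C(=O)C=CC(=C)[C@H]21` gives 92.8 nM
Compound 2 `C=C1C=CC(=O)[C@@H]2[C@H](Cc3ccc(OCOC)cc3)CC[C@H]12` gives 219 nM
Compound 3 `C=C1C=CC(=O)[C@@H]2[C@H](Cc3ccc(OCOC)c(F)c3)CC[C@H]12` gives 75.7 nM

Compound 2 has the highest number of the three, and the numbers of compound 1 and compound 3 both lie lower by more than the usual scatter. The next compound, compound 4 `C=C1C=CC(=O)[C@@H]2[C@H](Cc3ccc(O)cc3)CC[C@H]12` has no number yet. Measured against compound 2 it shows hydrogen in place of methoxymethyl on an oxygen on an aromatic ring and so carries hydrogen in place of methoxymethyl on an oxygen on an aromatic ring.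

Among the compounds with values here, only one measured step bears on this, and only indirectly. It is a 2.9-fold lower number from compound 2 to compound 3 (0.46 log units; beyond the scatter) and it is modest, but it comes from a different change, fluoro in place of hydrogen on an aromatic carbon. It therefore offers no more than a rough size for a single change in this small set. Compound 1, which also has a hydroxy group on its aromatic ring, gives 92.8 nM but differs from compound 2 in other places too, so it is weak support for a lower number.

A modest step in this assay toward a lower number is therefore expected, although a result within the scatter of compound 2 would not surprise. The expected change is a 2.2-fold lower number from compound 2 to compound 4 (0.34 log units; beyond the scatter) and it is uncertain. In this assay compound 4 is expected at 100 nM (from 35 nM to 300 nM).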

Compound 4, half-maximal inhibitory concentration: 218 nM
Compound 4: the middle estimate sits 2.2-fold (0.34 log units) below what was measured; low and high end bracket the measured number.
By their numbers in this assay, from the lowest: compounds 3 and 1 (each within the scatter of the next); then compounds 4 and 2 (each within the scatter of the next).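

In this assay, the exchange of methoxymethoxy for hydroxy gives a 1.0-fold lower number from compound 2 to compound 4 (0.00 log units; within the scatter), so the two compounds cannot be told apart at this oxygen on an aromatic ring. The earlier compounds had shown only that this part of the molecule responds to a fluoro in place of hydrogen on an aromatic carbon, with a 2.9-fold lower number from compound 2 to compound 3 (0.46 log units; beyond the scatter). The new pair adds that, in this read-out, the methoxymethyl on the oxygen can give way to hydrogen with the number staying within the scatter, although the result offers no explanation of this, and nothing measured here accounts for it.

Going by these compounds, it remains open whether the same holds for other groups at this oxygen, such as an ethyl or longer alkyl chain, a chain ending in a carboxylic acid or one ending in an amine, or whether an amine in place of the oxygen would fare alike. On these data alone, it is also open whether the step seen with fluoro on the methoxymethoxy compound would recur on the hydroxy compound, since that single change has been read only once.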